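This account rests on a few compounds, and the source may have more. Where it says the series, first, only, none or still open, it means among the compounds named here.

Working notes on the series. In a functional assay on HeLa cells (Homo sapiens) for antiproliferative activity, with a stated time of 5 days (a lower number here means a stronger inhibitor, a higher number a weaker inhibitor), compound 2 (`Cc1ccccc1-n1nc(-c2cccc3ccccc23)nc1N1C(=O)COC12C=CC(=O)C=C2`) gives 100 nM and sits within the scatter of compound 1 (`CC1OC2(C=CC(=O)C=C2)N(c2nc(-c3ccc4ccccc4c3)nn2-c2ccccc2)C1=O`) at 120 nM in the same read-out, while compound 3 (`Cc1ccc(-n2nc(-c3ccc4ccccc4c3)nc2N2C(=O)C(C)OC23C=CC(=O)C=C3)cc1`) at 530 nM lies clearly higher than both.

Compound 4 (`O=C1C=CC2(C=C1)OCC(=O)N2c1nc(-c2cccc3ccccc23)nn1-c1ccccc1`) departs from compound 2 by hydrogen in place of methyl on an aromatic carbon (hydrogen in place of methyl on an aromatic carbon, 2-methylphenyl to phenyl).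

Within the data shown here, only one measured step bears on this change: a 4.4-fold higher number from compound 1 to compound 3 (0.65 log units; beyond the scatter) for methyl in place of hydrogen on an aromatic carbon. Read backwards, that step points to a lower number when a methyl is lost. Among the measured compounds shown here, it comes from a pair whose remaining structure differs from compound 2, however, and no measured step covers a methyl ortho to a large group. Only a small shift toward a lower number is therefore expected, and it may not clear the scatter. The expected step is a 1.3-fold lower number from compound 2 to compound 4 (0.10 log units; within the scatter) on this reasoning. For compound 4 the estimate is 80 nM with 30 nM to 220 nM as the expected range.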

Compound 4, half-maximal inhibitory concentration: 70 nM
Compound 4: the middle estimate sits 1.1-fold (0.06 log units) above what was measured, and the stated range covers the measured number.
By their numbers in this assay, from the lowest: compounds 4, 2 and 1 (each within the scatter of the next); then compound 3.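

In this assay, the step on this core is a 1.4-fold lower number from compound 2 to compound 4 (0.15 log units; within the scatter), so the methyl ortho to a large group can go without a shift that clears the scatter. Compounds 2 and 4 are thus a pair in which the 2-methylphenyl to phenyl change leaves the read-out essentially in place, which the earlier step alone did not show. A methyl on this aromatic ring does not carry one fixed step size across the series, and the two cores give different answers: the same change on two cores in this assay, a 4.4-fold higher number (0.65 log units; beyond the scatter) from compound 1 to compound 3 and a 1.4-fold higher number (0.15 log units; within the scatter) from compound 4 to compound 2, 3.1-fold (0.49 log units) apart, beyond the scatter of two such steps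

The two pairs differ from each other in more than one place, so the compounds shown do not tell whether the gap follows the place of the methyl on the ring or the rest of the core. Also open, as far as these compounds go, is how a methoxy, a chlorine or an amine at the same place would read against compound 4.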